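The source may hold more compounds than are shown below. What is called first, only, known or untested is meant among the compounds shown, and "the series" means these compounds.

In a functional assay on MDA-MB-231 cells (Homo sapiens) for antiproliferative activity, with a stated time of 4 days (a higher number here means a weaker inhibitor, a lower number a stronger inhibitor), compound 3 (`CCCCCc1ccc2[nH]c(-c3ccc(C(F)(F)F)cc3)c(C=C(C#N)C#N)c2c1`) gives 78 nM and compound 2 (`CCCCc1ccc2[nH]c(-c3ccc(C(F)(F)F)cc3)c(C=C(C#N)C#N)c2c1`) gives 56 nM while compound 1 (`CCCCCCc1ccc2[nH]c(-c3ccc(OC)cc3)c(C=C(C#N)C#N)c2c1`) gives 46 nM on the same test. These three numbers all lie within the usual scatter of one another, so compound 3 is not set apart from the other two.

Compound 4 (`CCCCCCc1ccc2[nH]c(-c3ccc(C(F)(F)F)cc3)c(C=C(C#N)C#N)c2c1`) differs from compound 3 in one place (methyl in place of hydrogen on a saturated chain carbon, five bonds along the chain from an aromatic carbon) with a methyl in place of hydrogen on a saturated chain carbon, five bonds along the chain from an aromatic carbon. This turns the pentyl chain into a hexyl chain.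

The closest measured guide is a 1.4-fold higher number from compound 2 to compound 3 (0.14 log units; within the scatter) for the same swap made four bonds along the chain from an aromatic carbon, and that step stays within the scatter. Compound 1 also carries a hexyl chain, though with methoxy where compound 4 has trifluoromethyl, and compound 1 with 46 nM is a second, looser guide. One step is too little to establish a trend with chain length.

In this assay no change beyond the scatter is expected, and the estimated step of a 1.2-fold lower number from compound 3 to compound 4 (0.08 log units; within the scatter) has no firm direction. Compound 4 is estimated at 65 nM with an expected range of 30 nM to 140 nM in this test.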

Compound 4, half-maximal inhibitory concentration: 150 nM
For compound 4 the middle estimate is 2.3-fold (0.36 log units) below the measured one; measured number outside the range, above it.
By their numbers in this assay, from the lowest: compounds 1, 2, 3 and 4 (each within the scatter of the next, the first and the last beyond it).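

In this assay the methyl five bonds along the chain from an aromatic carbon gives a step of a 1.9-fold higher number from compound 3 to compound 4 (0.28 log units; within the scatter) that cannot by itself separate the pentyl chain of compound 3 from the hexyl chain of compound 4. The larger change, ethyl in place of hydrogen four bonds along the chain from an aromatic carbon, does give a readable difference: a 2.7-fold higher number from compound 2 to compound 4 (0.43 log units; beyond the scatter) shows that, with trifluoromethyl on the shared core, the hexyl chain gives a modestly weaker inhibitor than the butyl chain, so chain length can matter here even though neither single-carbon step is readable alone. With the hexyl chain held constant, trifluoromethyl in place of methoxy on an aromatic carbon gives a 3.3-fold higher number from compound 1 to compound 4 (0.51 log units; beyond the scatter) and shows that the hexyl chain does not fix the number, since the group on the other ring also makes a modest difference.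

Going by these compounds, it remains open whether an octyl chain would extend this difference in the trifluoromethyl compounds, and whether a butyl chain with methoxy or a chain ending in an amine would behave the same way. No data here explain any of these differences.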